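Restoring an Oxygen Ester at the Carbonyl Carbon

The source may report more compounds than this note shows. Statements on the series, on what has been measured and on what is new or still open speak of the compounds shown alone.

Compound 1 `CCCOC(=O)C1=C(C)NC(=O)NC1c1cccs1` gives 32%.
Compound 2 `CCSC(=O)C1=C(C)NC(=O)NC1c1cccs1` gives 1%.

In an assay on membranes from HeLa cells for displacement of a labelled ligand from adenosine receptor A3 (Homo sapiens), read by scintillation counting, with a stated time of 180 min, tested at 1 uM (a higher number here means more inhibition at the concentration tested (going by the name of the read-out), a lower number less inhibition), compound 2 stands lowest of the two measured compounds, with compound 1 its nearest neighbour at a markedly higher value. Compound 3 `CC1=C(C(=O)OCC2CCC2)C(c2cccs2)NC(=O)N1` differs from compound 2 by cyclobutylmethoxy in place of ethylsulfanyl on a carbonyl carbon. Going by the values given here, the one measured step bearing on this place is a number 31 percentage points lower from compound 1 to compound 2 (beyond the scatter), a large drop when ethylsulfanyl replaced propoxy. Compound 3 restores an oxygen-bearing group, cyclobutylmethoxy, so an upward step beyond the scatter, a number 29 percentage points higher from compound 2 to compound 3 (beyond the scatter), is expected. Compound 3 is estimated at 30%, within 10% to 55%.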

Compound 3, a percentage reported as inhibition, at one concentration (the size of the read-out at that concentration, not a potency): 1%
Estimate against measurement, compound 3: 29 percentage points above; measured number below the stated range.
By their numbers in this assay, from the lowest: compounds 2 and 3 (each within the scatter of the next); then compound 1.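

In this assay, putting cyclobutylmethoxy in place of ethylsulfanyl on the carbonyl carbon gives no change at the digits printed from compound 2 to compound 3 (within the scatter), so an oxygen at this place does not by itself restore the number. Both oxygen esters can also differ sharply: cyclobutyl in place of ethyl on the chain carbon gives a number 31 percentage points lower from compound 1 to compound 3 (beyond the scatter), so the rest of the chain matters here as well as the atom bound to the carbonyl. No available evidence explains these numbers.

From the compounds shown here alone, whether the number follows chain length or the ring remains open. An ethoxy, a butoxy or a cyclopropylmethoxy group at this place could help separate the two.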